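This account rests on a few compounds, and the source may have more. Where it says the series, first, only, none or still open, it means among the compounds named here.

The measured compounds in a functional assay on A-375 cells (Homo sapiens) for antiproliferative activity, read by trypan blue exclusion, with a stated time of 48 h, tested at 5 uM; a higher number here means a weaker effect of the compound at the concentration tested, a lower number a stronger effect:
- compound 1, `CC(=O)Nc1nc(-c2cccc(NS(=O)(=O)c3cccc(Br)c3)c2)cs1`: 67.4%
- compound 2, `CC(=O)Nc1nc(-c2cccc(NS(=O)(=O)c3ccc(C#CCO)cc3)c2)cs1`: 99.3%
- compound 3, `CC(=O)Nc1nc(-c2cccc(NS(=O)(=O)c3cccc(C#C[Si](C)(C)C)c3)c2)cs1`: < 1%

All three share one core and differ only in the group on the outer aromatic ring of the sulfonamide part. Compound 2 stands highest of the two plain numbers; compound 1 is its nearest neighbour, a number beyond the scatter lower. The value of compound 3 is not a number but a limit of the assay, (the limit of < 1% in this assay, at which 1 of the 3 values shown sits).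

Compound 4, `CCCCCC/C=C\c1ccc(S(=O)(=O)Nc2cccc(-c3csc(NC(C)=O)n3)c2)cc1`, has not yet been measured. It is compound 2 with a group of 8 heavy atoms (8 carbon; no ring) in place of a group of 4 heavy atoms (3 carbon, 1 oxygen; no ring), on an aromatic carbon. The measured step that bears on this change is the one in which a bromine atom on the same ring was exchanged for a larger carbon-rich group: a number at least 66.4 percentage points lower from compound 1 to compound 3 (beyond the scatter). That exchange produced a very large drop. Replacing the small hydroxy-bearing group of compound 2 with a longer all-carbon chain is a change of the same kind, so a marked drop is expected, of uncertain size. Compound 4 is therefore estimated at 45%, expected to lie between 5% and 90%. The expected step is a number 54.3 percentage points lower from compound 2 to compound 4 (beyond the scatter).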

Compound 4, a percentage reported as activity, at one concentration (the size of the read-out at that concentration, not a potency): 2.3%
Compound 4: middle estimate off by 42.7 percentage points, on the high side; the whole stated range lies above it.
By their numbers in this assay, from the lowest: compound 4; then compound 1; then compound 2. At a limit, below all of these: compound 3.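

In this assay, for the compounds shown here, the exchange at this place, para to a large group, gives a full step between two plain numbers (a number 97 percentage points lower from compound 2 to compound 4 (beyond the scatter)), whereas the only earlier step ended at a limit and fixed just a bound on its size. The read-out thus moves from almost no effect to a strong one at the tested concentration, with a large all-carbon group on this ring in place of 3-hydroxyprop-1-yn-1-yl. Compound 3 remains a limit of the assay, not a number: the limit of < 1% in this assay, at which 1 of the 4 values shown sits.

This step changes chain length, the hydroxy group and the triple bond all at once, so which of these matters stays unresolved. A saturated octyl chain, or a propynyl group ending in an amine, would help to separate them.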